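The compounds below may be only part of what the source reports. "The series", "measured", "known", "first", "only" and "open" are said of these compounds alone.

Compound 1 `CC(=O)Nc1ccc(S(=O)(=O)Oc2ccccc2C(C)C)cc1` gives 21000 nM in a functional assay on M21 cells (Homo sapiens) for antiproliferative activity, read by sulforhodamine B assay, with a stated time of 48 h; on this read-out higher numbers stand for weaker inhibition and lower numbers for stronger inhibition.
Compound 2 `CC(=O)Nc1ccc(S(=O)(=O)Oc2ccccc2I)cc1` gives 27000 nM in this assay.
Compound 3 `CCCNC(=O)Nc1ccc(S(=O)(=O)Oc2ccccc2C(C)C)cc1` gives 5100 nM in this assay.

Compound 2 has the highest number of the three in this assay, but its gap to compound 1 is within the scatter, so only compound 3 stands clearly apart from it. Compound 4 `CCCCCNC(=O)Nc1ccc(S(=O)(=O)Oc2ccccc2I)cc1` is not yet measured. It differs from compound 2 at a carbonyl carbon: pentylamino in place of methyl on a carbonyl carbon. The step that bears on this is the one where an amino chain replaced the methyl on a carbonyl carbon: a 4.1-fold lower number from compound 1 to compound 3 (0.61 log units; beyond the scatter), a modest drop in the number, that is, stronger inhibition. The other step, a 1.3-fold higher number from compound 1 to compound 2 (0.11 log units; within the scatter), changes the group on the aromatic carbon and shows nothing beyond the scatter, so the iodo group of compound 2 is not expected to alter the outcome. Among the compounds with values here, the pentylamino chain is longer than the propylamino chain, and no measured compound shows what that extra length adds, so the expectation rests on the one comparable step. Compound 4 is therefore expected to show a 3.9-fold lower number from compound 2 to compound 4 (0.59 log units; beyond the scatter). Compound 4 is estimated at 7000 nM, with a range from 2500 nM to 20000 nM.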

Compound 4, half-maximal inhibitory concentration: 5900 nM
Compound 4: middle estimate off by 1.2-fold (0.07 log units), on the high side; measured number inside the range.
By their numbers in this assay, from the lowest: compounds 3 and 4 (each within the scatter of the next); then compounds 1 and 2 (each within the scatter of the next).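

In this assay, replacing the methyl on the carbonyl carbon with pentylamino gives a 4.6-fold lower number from compound 2 to compound 4 (0.66 log units; beyond the scatter), which means stronger inhibition. Within the data shown here, until now, the gain from an amino chain at this carbon had been seen only with the isopropyl group on the aromatic carbon, in the step of a 4.1-fold lower number from compound 1 to compound 3 (0.61 log units; beyond the scatter); it now appears with the iodo group too, so in these two pairs it does not depend on which of the two groups is present. Nothing available explains why the number falls at this position.

As far as these compounds go, compound 3 and compound 4 differ in two places, so the effect of chain length on its own remains unknown. From the compounds shown here alone, it is also open how a shorter ethylamino chain, a longer heptylamino chain or a ring such as cyclohexylamino would fare at this carbon.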